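Swapping isobutyl for 4-fluorobenzyl on the aryl amine

This account rests on a few compounds, and the source may have more. Where it says the series, first, only, none or still open, it means among the compounds named here.

This account concerns a small set of cyclopropane carboxylic acids built around a shared core and differing in the substituents carried on the nitrogen bound to the aromatic ring. Compound 1 `COc1cc(N(CC2CC2)c2ccc(Cl)c(Cl)c2)cnc1C(=O)[C@H]1C[C@@H]1C(=O)O` gives 4.3 uL/min in an ADME assay on cells (Hepatocyte, Homo sapiens) for metabolic stability, read by LC-MS, with a stated time of 60 min, tested at 1 uM (a lower number here means slower removal, a higher number faster removal of the compound), compound 2 `COc1nc(C(=O)[C@@H]2C[C@H]2C(=O)O)ncc1N(CC1CC1)c1ccc(Cl)c2ccccc12` gives 15 uL/min in this assay, and compound 3 `COc1cc(N(CC(C)C)c2cccc(C(F)(F)F)c2)cnc1C(=O)[C@H]1C[C@@H]1C(=O)O` gives 2.9 uL/min. Compound 3 thus stands at the lowest of the three numbers, but its gap to compound 1 is within the usual scatter, so the two cannot be ordered; only its gap to compound 2 lies beyond the scatter, so compound 3 is removed more slowly than compound 2.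

Compound 4 `COc1cc(N(Cc2ccc(F)cc2)c2cccc(C(F)(F)F)c2)cnc1C(=O)[C@H]1C[C@@H]1C(=O)O` has not yet been measured in this assay. Its structure differs from compound 3 in one place: 4-fluorophenyl in place of isopropyl on a saturated chain carbon bound to a nitrogen on an aromatic ring. For the measured compounds named here, no pair of measured compounds in this set shows a comparable difference, so no measured step can guide the expectation directly.

The author expects the step of a 2.2-fold higher number from compound 3 to compound 4 (0.35 log units; beyond the scatter) to be upward and of modest size, possibly reaching beyond the scatter. Compound 4 is therefore estimated to give 6.5 uL/min in this assay, with a plausible range from 2.5 uL/min to 16 uL/min.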

Compound 4, intrinsic clearance in a liver preparation (reported as CLH), per the amount of preparation that the assay uses in the Hepatocyte assay: 4.2 uL/min
Compound 4: middle estimate off by 1.5-fold (0.19 log units), on the high side, and the stated range covers the measured number.
By their numbers in the Hepatocyte assay, from the lowest: compounds 3, 4 and 1 (each within the scatter of the next); then compound 2.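

For the compounds shown here, until now no measured pair had isolated this position, and in the Hepatocyte assay the exchange of isopropyl for 4-fluorophenyl on a saturated chain carbon bound to a nitrogen on an aromatic ring gives a 1.4-fold higher number from compound 3 to compound 4 (0.16 log units; within the scatter), so the two compounds cannot be ordered and the larger, ring-bearing group is tolerated here without a difference this read-out can resolve. In a physicochemical assay for lipophilicity, read by LC-MS, in phosphate buffer, measured as octanol-water partition, at pH 7.4 (a lower number here means a more polar compound, a higher number a more lipophilic compound), compound 3 gives 1.6 and compound 4 gives 1.9, which is a number 0.30 log units higher from compound 3 to compound 4 (within the scatter), so neither read-out separates the pair. No evidence at hand bears on the origin of these results.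

The compounds shown leave open whether this tolerance extends to other groups at the same place, such as a plain phenyl without fluorine, a longer chain, or a chain ending in an amine or a carboxylic acid. They also leave open whether the same exchange would read alike with a different group in place of the trifluoromethyl-bearing aryl ring on that nitrogen, since this single pair holds that ring fixed.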